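A few compounds are considered here, and "the series" means these few. Any claim that something is new, unique, unknown or untested is made for them only; others in the source may bear on it.

Going by the values given here, compound 2, `Nc1sc(-c2ccccc2)cc1C(=O)c1ccc(Cl)cc1`, stands at the weaker end of the two numbers so far: in an assay on CHO cells for positive allosteric modulation of adenosine receptor A1 (Homo sapiens), read by ERK phosphorylation, tested at 10 uM (a lower number here means a stronger effect, a higher number a weaker effect of the compound at the concentration tested), compound 2 gives 16%, while compound 1, `Nc1sc(-c2cncnc2)cc1C(=O)c1ccccc1`, gives 2% in this assay. The two compounds differ in two places, so their gap cannot be tied to either one. Compound 3, `Nc1sc(-c2cncnc2)cc1C(=O)c1ccc(Cl)cc1`, has not yet been measured in this assay. It takes compound 2 and makes one change: pyrimidin-5-yl in place of phenyl on an aromatic carbon. Compound 1 also carries the pyrimidin-5-yl group and sits stronger than compound 2 by a gap beyond the usual scatter, which is the only hint available. On that basis the step of a number 9 percentage points lower from compound 2 to compound 3 (within the scatter) is expected to run toward a stronger effect, though a step of that size could still fall near the usual scatter. The estimate for compound 3 in this assay is 7%, with a likely range from -8% to 22%.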

Compound 3, a percentage reported as activity, at one concentration (the size of the read-out at that concentration, not a potency): 4%
Beside the measured number, compound 3's estimate is 3 percentage points above it; the range from low to high includes it.
By their numbers in this assay, from the lowest: compounds 1 and 3 (each within the scatter of the next); then compound 2.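

In this assay the step of a number 12 percentage points lower from compound 2 to compound 3 (beyond the scatter) isolates the change of phenyl to pyrimidin-5-yl on the aromatic carbon next to the ring sulfur, and it lies beyond the scatter, so this position responds to the ring change alone, which the two-place gap between compound 1 and compound 2 could not show. With pyrimidin-5-yl in place, the step of a number 2 percentage points higher from compound 1 to compound 3 (within the scatter) for chloro in place of hydrogen stays within the scatter, so no effect of the chloro can be read on this background. Nothing measured here bears on why the ring change shifts the number.

From the compounds shown here alone, whether pyridin-3-yl, with a single ring nitrogen, would behave like pyrimidin-5-yl at this position remains open. So does whether a carboxylic acid or a methoxy group in place of the chloro would leave the number unchanged.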